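The compounds below may be only part of what the source reports. "The series", "measured", "known", "first", "only" and "open" are said of these compounds alone.

The three measured compounds share one core. Compound 1 `CCc1ccc(-c2nc3c(c(C)nn3-c3ccccc3)c(-c3ccccc3[N+](=O)[O-])c2C#N)cc1` carries a nitro group on its pendant ring; in an ADME assay on BJ cells (Homo sapiens) for cytotoxicity, with a stated time of 72 h (on this read-out lower numbers stand for an effect already at smaller amounts and higher numbers for an effect only at larger amounts of compound), compound 1 gives > 20000 nM, which is a limit of the assay rather than a number. Compound 2 `CCc1ccc(-c2nc3c(c(C)nn3-c3ccccc3)c(-c3ccccc3I)c2C#N)cc1` has iodo in place of nitro on an aromatic carbon; in this assay compound 2 gives > 20000 nM, again a limit and not a number. The step that the two limits leave unreadable from compound 1 to compound 2 therefore cannot be read from the two limits. For the measured compounds named here, compound 3 `Cc1ccc(-c2nc3c(c(C)nn3-c3ccccc3)c(-c3ccccc3O)c2C#N)cc1` is the single member with a number: in this assay compound 3 gives 22200 nM. That number lies close to the limit of > 20000 nM in this assay, at which 2 of the 3 values shown sit, so compound 3 stands at the very edge of what the assay reports, and it is the only number shown.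

Compound 4 `Cc1nn(-c2ccccc2)c2nc(-c3ccc(C#N)cc3)c(C#N)c(-c3ccccc3O)c12` differs from compound 3 by cyano in place of methyl on an aromatic carbon. Going by the values given here, no measured step bears on this change: the one step available concerns iodo in place of nitro and is in any case unreadable. With nothing to lean on, no step beyond the scatter is expected in either direction. Compound 4 is expected to give 20000 nM in this assay, within a range from 8000 nM to 50000 nM. The expected step is therefore a 1.1-fold lower number from compound 3 to compound 4 (0.05 log units; within the scatter).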

Compound 4, half-maximal effective concentration: > 20000 nM
Compound 4 was reported as a limit; the forecaster's own chance of this, stated with the estimate: 50%; the middle value sits exactly at the limit.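

In this assay compound 4 gives > 20000 nM, which is a limit and not a number, so no new step can be read between compound 3 and compound 4. The compounds shown leave open whether any of these changes on the shared core shifts the value in this assay at all; only compound 3 carries a number.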